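The source may report more compounds than this note shows. Statements on the series, on what has been measured and on what is new or still open speak of the compounds shown alone.

Measured so far:
compound 1, `C[C@H](Nc1nc(N)nc(N)c1C#N)c1cc2ccc(F)cn2c(=O)c1-c1ccccc1` — 42%
compound 2, `Cc1nc(N)nc(N[C@@H](C)c2cc3ccc(F)cn3c(=O)c2-c2ccccc2)c1C#N` — 8%

Among the measured compounds shown here, in an ADME assay on microsomes from liver (Mus musculus), read by LC-MS, using NADPH, with a stated time of 30 min, tested at 1 uM (a lower number here means that less of the compound is left, a higher number that more of the compound is left), compound 1 gives 42%, the highest of the two numbers; the only neighbour, compound 2, gives 8%. For the measured compounds named here, the one measured step, a number 34 percentage points lower from compound 1 to compound 2 (beyond the scatter), is methyl in place of amino on an aromatic carbon and is large.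

Compound 3, `C[C@H](Nc1nc(N)nc(N)c1C#N)c1c(-c2ccccc2)c(=O)n2cc(F)ccc2c1C1CC1`, is not yet measured. It differs from compound 1 by cyclopropyl in place of hydrogen on an aromatic carbon. Going by the values given here, no measured step concerns this site or this kind of change, so the step from compound 1 to compound 2 bears on it only in showing how far a single change can move this read-out. For compound 3 a moderate drop is expected, a number 14 percentage points lower from compound 1 to compound 3 (beyond the scatter), rather than a rise. For compound 3 the expected value is 28%, with a range from 10% to 50%.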

Compound 3, percent of the compound remaining: 87%
Compound 3: middle estimate off by 59 percentage points, on the low side; the measured number lies above the stated range.
By their numbers in this assay, from the lowest: compound 2; then compound 1; then compound 3.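

In this assay, cyclopropyl in place of hydrogen on an aromatic carbon of the shared core gives a number 45 percentage points higher from compound 1 to compound 3 (beyond the scatter). Among the compounds shown here, this is the only measured change at this position, ortho to a large group and meta to a phenyl group, and it shows that a substituent here can raise the read-out by a large step, whereas the one earlier step, at a different site, lowered it. Nothing measured on these compounds accounts for the rise.

Whether the rise is specific to cyclopropyl or extends to other groups at this position remains open, with methyl, ethyl and cyclobutyl absent from the compounds shown. Also open, from the compounds shown here alone, is whether cyclopropyl at this position would give a similar rise on compound 2, which carries methyl in place of amino.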